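Swapping a sulfanyl link for a benzylamino link on a diaminoquinoxaline

A few compounds are considered here, and "the series" means these few. Any claim that something is new, unique, unknown or untested is made for them only; others in the source may bear on it.

Of the compounds shown here, three sharing one core have been measured in a functional assay on HOP-92 cells (Homo sapiens) for inhibition, read by sulforhodamine B assay, with a stated time of 48 h; a higher number here means a weaker inhibitor of growth, a lower number a stronger inhibitor of growth. Compound 1 `CCOC(=O)[C@H](CCC(=O)O)NC(=O)c1ccc(Sc2nc3cc(N)cc(N)c3nc2-c2ccccc2)cc1` gives 3800 nM, and compound 3 `COc1cc(CNc2nc3cc(N)cc(N)c3nc2-c2ccccc2)cc(OC)c1OC` gives 1200 nM. Compound 2 `Nc1cc(N)c2nc(-c3ccccc3)c(Sc3ccc(F)cc3)nc2c1` gives 22900 nM, the highest of the three numbers, and its gaps to compound 1 and to compound 3 both lie beyond the scatter. Compound 4 `Nc1cc(N)c2nc(-c3ccccc3)c(NCc3ccc(F)cc3)nc2c1` has not yet been measured. It differs from compound 2 in one place: (4-fluorobenzyl)amino in place of (4-fluorophenyl)sulfanyl on an aromatic carbon. Going by the values given here, no measured pair shows this exact change, but compound 3, which also carries a benzylamino group, sits far lower than compound 2. The step of a 6.5-fold lower number from compound 2 to compound 4 (0.82 log units; beyond the scatter) is therefore expected to be downward and beyond the scatter. Compound 4 is estimated at 3500 nM, within 900 nM to 14000 nM.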

Compound 4, concentration for 50% growth inhibition: 3310 nM
Beside the measured number, compound 4's estimate is 1.1-fold (0.02 log units) above it, within the range that was stated.
By their numbers in this assay, from the lowest: compound 3; then compounds 4 and 1 (each within the scatter of the next); then compound 2.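

In this assay, (4-fluorobenzyl)amino in place of (4-fluorophenyl)sulfanyl on this aromatic carbon gives a 6.9-fold lower number from compound 2 to compound 4 (0.84 log units; beyond the scatter). Going by these compounds alone, this is the first direct reading of the change at this position, with the rest of the molecule held constant, and it shows that the link to the 4-fluorophenyl ring alone can move the number beyond the scatter. No supporting measurement accounts for the step. The compounds shown leave open whether the amino nitrogen or the added methylene carries the step. A (4-fluorophenyl)amino group or a (4-fluorobenzyl)sulfanyl group at this position would separate the two.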